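Trimming the Isopropyl Back to a Methyl

This account rests on a few compounds, and the source may have more. Where it says the series, first, only, none or still open, it means among the compounds named here.

Among the measured compounds shown here, compound 2 `CC(C)c1nc(-c2ccccc2)cc2nn(-c3ccccc3)cc12` is the only compound here with a numerical result: in a functional assay on K562 cells (Homo sapiens) for inhibition, read by fluorescence, with a stated time of 72 h (on this read-out lower numbers stand for stronger inhibition of growth and higher numbers for weaker inhibition of growth), compound 2 gives 36800 nM. Compound 1 `Cc1nc(CCO)cc2nn(-c3ccccc3)cc12` sits at the limit of > 100000 nM in this assay, at which 1 of the 2 values shown sits, so its reading of > 100000 nM in this assay is a limit rather than a number. For the measured compounds named here, no step between measured compounds has been recorded. Compound 3 `Cc1nc(-c2ccccc2)cc2nn(-c3ccccc3)cc12` differs from compound 2 by methyl in place of isopropyl on an aromatic carbon. The step of a 1.4-fold higher number from compound 2 to compound 3 (0.13 log units; within the scatter) is expected to be small, leaning toward weaker inhibition of growth, close to the scatter. Compound 3 is therefore estimated at 50000 nM, within 15000 nM to 150000 nM.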

Compound 3, concentration for 50% growth inhibition: 6300 nM
The estimate for compound 3 lay 7.9-fold (0.90 log units) above the measured number; the whole stated range lies above it.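

Trimming isopropyl to methyl on the aromatic carbon next to the ring nitrogen proves to be more than a minor edit: this assay shows a 5.8-fold lower number from compound 2 to compound 3 (0.77 log units; beyond the scatter). With that methyl kept, phenyl in place of 2-hydroxyethyl gives an at least 15-fold lower number from compound 1 to compound 3 (1.20 log units; beyond the scatter). This second step rests on a limit rather than a number: the limit of > 100000 nM in this assay, at which 1 of the 3 values shown sits.

From the compounds shown here alone, what an ethyl group or a bare hydrogen would do on that same carbon remains open, so two groups define no trend there. Going by these compounds, the effect of an amine or a carboxylic acid in place of the phenyl group is also open.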